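The source may hold more compounds than are shown below. What is called first, only, known or untested is meant among the compounds shown, and "the series" means these compounds.

Measured in a functional assay on K562 cells (Homo sapiens) for antiproliferative activity, read by MTT assay; on this read-out lower numbers stand for stronger inhibition and higher numbers for weaker inhibition:
Compound 1 `O=C(CCCCCNC(=S)N/N=C(\c1ccccc1)c1ccccc1[N+](=O)[O-])NO`: 2330 nM
Compound 2 `O=C(CCCCCNC(=S)N/N=C(\c1ccccc1)c1cccc([N+](=O)[O-])c1)NO`: 1630 nM

Of the two numbers available in this assay, compound 2 at 1630 nM cannot be separated from compound 1 at 2330 nM. The step between them is a 1.4-fold lower number from compound 1 to compound 2 (0.16 log units; within the scatter). The next compound, compound 3 `COc1ccccc1/C(=N/NC(=S)NCCCCCC(=O)NO)c1ccccc1`, is not yet measured. It differs from compound 2 by 2-methoxyphenyl in place of 3-nitrophenyl on a carbon with a double bond to nitrogen. Among the measured compounds shown here, only the step from compound 1 to compound 2 bears on this site, and no measurement yet shows what happens when the nitrophenyl group is exchanged for a methoxyphenyl group. With that single step inside the scatter, no step beyond the scatter is expected in this assay, though the uncertainty is wide. The expected change is a 1.2-fold higher number from compound 2 to compound 3 (0.07 log units; within the scatter). For compound 3 the estimated value is 1900 nM, with an expected range from 800 nM to 4500 nM.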

Compound 3, half-maximal inhibitory concentration: 3560 nM
For compound 3 the middle estimate is 1.9-fold (0.27 log units) below the measured one; low and high end bracket the measured number.
By their numbers in this assay, from the lowest: compounds 2, 1 and 3 (each within the scatter of the next, the first and the last beyond it).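

In this assay, this site can move the number beyond the scatter, with a 2.2-fold higher number from compound 2 to compound 3 (0.34 log units; beyond the scatter) on placing 2-methoxyphenyl in place of 3-nitrophenyl, though this step is only modest. The exchange of methoxy in place of nitro on an aromatic carbon gives a 1.5-fold higher number from compound 1 to compound 3 (0.18 log units; within the scatter) and stays within the scatter, so compound 3 is set apart from compound 2 but cannot be separated from compound 1. No measured evidence is available to account for either step.

The compounds shown leave open whether the step from compound 2 to compound 3 follows from the change of group or from where the group sits on the ring. They also leave open how an amine or a carboxylic acid on this phenyl ring would read at this site.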